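The source may report more compounds than this note shows. Statements on the series, on what has been measured and on what is new or still open speak of the compounds shown alone.

Measured so far:
compound 1 `CCN1CCN(CC(=O)Nc2nc3ccccc3[nH]2)CC1`, in a functional assay, read by spectrophotometry, with a stated time of 30 min, tested at 100 ug/mL (on this read-out lower numbers stand for a weaker effect and higher numbers for a stronger effect at the one concentration tested), compound 1 gives 45.7%;
compound 2 `O=C(CN1CCN(c2ccccc2F)CC1)Nc1nc2ccccc2[nH]1`, in this assay compound 2 gives 47.7%.

Within the data shown here, the two numbers sit within the scatter of each other: the one measured step, a number 2 percentage points higher from compound 1 to compound 2 (within the scatter), is within the scatter. Compound 3 `COc1ccc(N2CCN(CC(=O)Nc3nc4ccccc4[nH]3)CC2)cc1` is not yet measured; it differs from compound 2 in one place, (4-methoxyphenyl in place of 2-fluorophenyl on an amine nitrogen in a ring). Among the measured compounds shown here, only the step from compound 1 to compound 2, which also changes the group on this ring nitrogen, bears on it, and that step was within the scatter. No step beyond the scatter is therefore expected in this assay: the estimated step is a number 0.7 percentage points lower from compound 2 to compound 3 (within the scatter). For compound 3 the expected value in this assay is 47%, with a range from 30% to 64%.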

Compound 3, a percentage reported as activity, at one concentration (the size of the read-out at that concentration, not a potency): 38.9%
The estimate for compound 3 lay 8.1 percentage points above the measured number; the range from low to high includes it.
By their numbers in this assay, from the lowest: compounds 3, 1 and 2 (each within the scatter of the next).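

In this assay, both new steps, a number 8.8 percentage points lower from compound 2 to compound 3 (within the scatter) and a number 6.8 percentage points lower from compound 1 to compound 3 (within the scatter), are within the scatter. Among these compounds, this amine nitrogen in a ring has now carried ethyl, 2-fluorophenyl and 4-methoxyphenyl with no step beyond the scatter, and this includes the first change that brings in a hydrogen-bond acceptor. No supporting measurement bears on this result. Still open, going by these compounds, is whether a carboxylic acid chain or a benzyl group here would give a step beyond the scatter. 4-Fluorophenyl and 2-methoxyphenyl would separate the substituent's identity from its ring position.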